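The source may report more compounds than this note shows. Statements on the series, on what has been measured and on what is new or still open speak of the compounds shown alone.

Measured compounds in an assay on HEK293 cells for displacement of a labelled ligand from D(3) dopamine receptor (Rattus norvegicus), with a stated time of 1 h; a lower number here means a stronger inhibitor, a higher number a weaker inhibitor:
compound 1 `CCCN(CCCCCc1ccc(O)c(O)c1)C1CCc2nc(N)sc2C1` gives 2.59 nM
compound 2 `CCCN(CCCCCc1cc(O)ccc1O)[C@H]1CCc2nc(N)sc2C1` gives 0.78 nM

Compound 2 holds the lowest of the two numbers in this assay; its nearest neighbour is compound 1, which shows a higher number by a step beyond the usual scatter. Compound 2 is drawn with an S configuration at the stereocentre on the saturated ring carbon.

Compound 3 `CCCN(CCCCCc1cc(O)ccc1O)C1CCc2nc(N)sc2C1` has not yet been measured in this assay. Its difference from compound 2 is the two compounds have the same atoms and bonds; at least one stereo element is drawn with a configuration in one of them and without one in the other: 1 of 1 stereo elements differ; a stereocentre at a saturated ring carbon is drawn S in compound 2 and without a configuration in compound 3. The two compounds share every atom and bond; only the drawn configuration at that one saturated ring carbon is absent in compound 3.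

Within the data shown here, no step between two measured compounds that differ only in this way is available, so the size of the effect cannot be read from the data. Since compound 3 is expected to contain material of the S configuration alongside material without it, its number in this assay is expected to be somewhat higher than that of compound 2, with a step of a 1.9-fold higher number from compound 2 to compound 3 (0.28 log units; within the scatter) that may lie near the edge of the scatter. The estimate for compound 3 in this assay is 1.5 nM, expected to fall between 0.7 nM and 4 nM.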

Compound 3, inhibition constant: 1.01 nM
For compound 3 the middle estimate is 1.5-fold (0.17 log units) above the measured one; the measured number falls inside the stated range.
By their numbers in this assay, from the lowest: compounds 2 and 3 (each within the scatter of the next); then compound 1.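

In this assay the loss of the drawn configuration gives a 1.3-fold higher number from compound 2 to compound 3 (0.11 log units; within the scatter), so the S form and the material drawn without a configuration cannot be told apart at this saturated ring carbon. With no configuration drawn in either compound, 2,5-dihydroxyphenyl in place of 3,4-dihydroxyphenyl gives a 2.6-fold lower number from compound 1 to compound 3 (0.41 log units; beyond the scatter), which shows a modest effect of the hydroxyl pattern on the aryl group, separate from any question of drawn configuration; the earlier comparison of compound 1 with compound 2 mixed these two changes. The closeness of the values for compound 2 and compound 3 can be tied to no more than this: the fact that one of compounds 2 and 3 is drawn with a defined configuration and the other without, at the place where they differ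

The compounds shown leave open how a form drawn R at the saturated ring carbon would behave, and so how much configuration at this position matters in this assay. Also open, on these data alone, is whether both hydroxyl groups of the 2,5-dihydroxyphenyl are needed, for instance with a single hydroxyl or with methoxy groups in their place, and how a shorter or longer chain to the amine nitrogen would read.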